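A few compounds are considered here, and "the series" means these few. Any claim that something is new, unique, unknown or untested is made for them only; others in the source may bear on it.

Measured in an ADME assay on HEp-2 cells (Homo sapiens) for cytotoxicity; a higher number here means that more compound is tolerated, a lower number that less compound is tolerated:
- compound 1 `CC(C)CCn1c(Cn2c(=O)n(C(C)C)c3ccccc32)nc2cc(CNC3CC3)ccc21` gives 17200 nM
- compound 2 `CC(C)CCn1c(Cn2c(=O)n(C(C)C)c3ccccc32)nc2cccc(CN)c21` gives 11000 nM

In this assay compound 2 at 11000 nM stands within the usual scatter of compound 1 at 17200 nM and neither number can be separated from the other. Going by the values given here, compound 3 `COC(=O)c1cccc2nc(Cn3c(=O)n(C(C)C)c4ccccc43)n(CCC(C)C)c12` carries methoxycarbonyl in place of aminomethyl on an aromatic carbon and has no measurement yet. Among the compounds with values here, no measured pair shows what such a change does, so only a small upward move or none beyond the scatter is expected in this assay and the estimated step is a 1.8-fold higher number from compound 2 to compound 3 (0.26 log units; within the scatter) in all. Compound 3 is estimated at 20000 nM with an expected range from 7000 nM to 60000 nM for now.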

Compound 3, half-maximal cytotoxic concentration: 25300 nM
Compound 3: middle estimate off by 1.3-fold (0.10 log units), on the low side; measured number inside the range.
By their numbers in this assay, from the lowest: compounds 2, 1 and 3 (each within the scatter of the next, the first and the last beyond it).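

In this assay, methoxycarbonyl in place of aminomethyl on this aromatic carbon gives a 2.3-fold higher number from compound 2 to compound 3 (0.36 log units; beyond the scatter) as a modest step, so the group at this position can move the number beyond the scatter. The higher number comes with the group that has no hydrogen-bond donor, so a donor here is not required for more compound to be tolerated. No available measurement gives a reason for this step. As far as these compounds go, it remains open whether a carboxylic acid or an aminoethyl chain on this carbon would move the number, and in which direction. From the compounds shown here alone, whether the step reflects losing aminomethyl or gaining methoxycarbonyl also remains open.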